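This account rests on a few compounds, and the source may have more. Where it says the series, first, only, none or still open, it means among the compounds named here.

Compound 1 `CCOC(=O)c1cc2sccc2n1Cc1ccc(OC)cc1` was tested in an ADME assay on HEK-293T cells (Homo sapiens) for cytotoxicity, read by luminescence, with a stated time of 24 h; on this read-out lower numbers stand for higher toxicity in this test and higher numbers for lower toxicity in this test. In this assay compound 1 gives > 100000 nM, a limit of the assay rather than a number. Compound 2 `COc1ccc(Cn2c(C(=O)NC(C)c3ccccc3)cc3sccc32)cc1` gives > 100000 nM, again a limit. Compound 3 `COc1ccc(Cn2c(C(=O)N3CCCCC3)cc3sccc32)cc1` gives > 100000 nM, also a limit. Because of the limit of > 100000 nM in this assay, at which 3 of the 3 values shown sit, the steps a step that the two limits leave unreadable from compound 1 to compound 2, a step that the two limits leave unreadable from compound 1 to compound 3 and a step that the two limits leave unreadable from compound 2 to compound 3 cannot be sized. Compound 4 `COc1ccc(Cn2c(C(=O)N3CCC(C(=O)O)CC3)cc3sccc32)cc1` has not yet been measured; it differs from compound 1 by 4-carboxypiperidin-1-yl in place of ethoxy on a carbonyl carbon. The measured changes at the same carbonyl carbon give no readable size, so no shift beyond the scatter is expected, and compound 4 is estimated at 100000 nM, most likely again only a limit, with a range from 50000 nM to 300000 nM. This corresponds to an expected step of a number no higher from compound 1 to compound 4 (the limit leaves the size open).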

Compound 4, half-maximal cytotoxic concentration: > 100000 nM
Compound 4 gave a limit, no number; the forecaster's own chance of this, stated with the estimate: 85%; the middle value sits exactly at the limit.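

The steps linking compound 4 to compound 1, compound 2 and compound 3 cannot be read, because each value is only a limit: the limit of > 100000 nM in this assay, at which 4 of the 4 values shown sit.

Left open is the actual cytotoxic concentration of each compound in this assay, and whether any of these changes on the carbonyl carbon alters it.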